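Acetyl removal on the ring amine, carried across two cores

The source may report more compounds than this note shows. Statements on the series, on what has been measured and on what is new or still open speak of the compounds shown alone.

Compound 1 `COc1ncc(-c2ccc3nc(NC(C)=O)nn3c2)cc1NS(=O)(=O)c1ccc(C)cc1` and compound 2 `COc1ncc(-c2ccc3nc(N)nn3c2)cc1NS(=O)(=O)c1ccc(C)cc1` share a core and the rest of the molecule; they differ by hydrogen in place of acetyl on a nitrogen on an aromatic ring. In a functional assay on HCT-116 cells (Homo sapiens) for antiproliferative activity, read by MTT assay, with a stated time of 48 h (a higher number here means a weaker inhibitor, a lower number a stronger inhibitor), compound 1 gives 600 nM, while compound 2 gives 3400 nM, so the change produced a 5.7-fold higher number from compound 1 to compound 2 (0.75 log units; beyond the scatter). Compound 3 `COc1ncc(-c2ccn3nc(NC(C)=O)nc3c2)cc1NS(=O)(=O)c1ccc(F)cc1` keeps the acetamido group but differs from compound 1 in more than one place; the difference between the two cores is not broken down here. In this assay compound 3 gives 1320 nM, a number lying between those of compound 1 and compound 2. Compound 4 `COc1ncc(-c2ccn3nc(N)nc3c2)cc1NS(=O)(=O)c1ccc(F)cc1` is not yet measured; it differs from compound 3 by hydrogen in place of acetyl on a nitrogen on an aromatic ring, the same change as from compound 1 to compound 2, at a place described in the same words. For the measured compounds named here, the expectation for compound 4 is a step of a 5.3-fold higher number from compound 3 to compound 4 (0.72 log units; beyond the scatter), resting on the single measured instance of this change, a 5.7-fold higher number from compound 1 to compound 2 (0.75 log units; beyond the scatter), since no second instance on another core is available to check it. Compound 4 is therefore estimated at 7000 nM, within a range from 3000 nM to 17000 nM.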

Compound 4, half-maximal inhibitory concentration: 820 nM
Compound 4: the middle estimate sits 8.5-fold (0.93 log units) above what was measured; measured number below the stated range.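

On the core of compound 3, hydrogen in place of acetyl gives, in this assay, a 1.6-fold lower number from compound 3 to compound 4 (0.21 log units; within the scatter), so the loss of activity seen on the core of compound 1 does not carry over to this second pair, and the two steps differ: the same change on two cores in this assay, a 5.7-fold higher number (0.75 log units; beyond the scatter) from compound 1 to compound 2 and a 1.6-fold lower number (0.21 log units; within the scatter) from compound 3 to compound 4, 9.1-fold (0.96 log units) apart, beyond the scatter of two such steps. In this series, then, the step measured on one core is not a safe guide to the same change on the other, and the acetamido group cannot be treated as contributing a fixed amount. What this does not show is the source of the difference, since the two pairs differ both in the core and in methyl against fluorine on the aryl group of the sulfonamide, and just two pairs give no general rule.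

The compounds shown leave open whether the core or that methyl or fluorine governs the step. They also leave open how other groups on the same nitrogen, such as a propionyl group, a urea or a simple methyl, would behave on each core.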